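The source may report more compounds than this note shows. Statements on the series, on what has been measured and on what is new or still open speak of the compounds shown alone.

Compound 1 `COc1cc(NC(=O)Nc2cc(Nc3ccc(C)c(F)c3)ncn2)cc(OC)c1`: 39.7%
Compound 2 `Cc1ccc(Nc2cc(NC(=O)Nc3c(Cl)cccc3Cl)ncn2)cc1C`: 41.3%
Compound 3 `O=C(Nc1cc(Nc2ccc(F)c(Cl)c2)ncn1)Nc1c(Cl)cccc1Cl`: 47.3%

In a functional assay on NCI-H226 cells (Homo sapiens) for inhibition, read by MTT assay, with a stated time of 48 h, tested at 10 uM (on this read-out lower numbers stand for less inhibition and higher numbers for more inhibition at the one concentration tested (going by the name of the read-out)), compound 1 gives the lowest of the three numbers shown, although its gaps to compound 2 and to compound 3 both lie within the scatter, so no order among the three can be claimed. Compound 4 `COc1cc(NC(=O)Nc2cc(Nc3ccc(F)c(Cl)c3)ncn2)cc(OC)c1` differs from compound 1 in one place: 3-chloro-4-fluorophenyl in place of 3-fluoro-4-methylphenyl on a nitrogen on an aromatic ring. Among the measured compounds shown here, one measured step bears on this change, the same group entering in place of 3,4-dimethylphenyl, a number 6 percentage points higher from compound 2 to compound 3 (within the scatter), which stayed within the scatter. The group leaving compound 1 is 3-fluoro-4-methylphenyl rather than 3,4-dimethylphenyl, so that step is a close but not exact guide. The expected step is therefore small and upward at most, a number 4.3 percentage points higher from compound 1 to compound 4 (within the scatter). The estimate for compound 4 in this assay is 44%, within a range from 30% to 58%.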

Compound 4, a percentage reported as inhibition, at one concentration (the size of the read-out at that concentration, not a potency): 36.7%
Estimate against measurement, compound 4: 7.3 percentage points above, within the range that was stated.
By their numbers in this assay, from the lowest: compounds 4, 1, 2 and 3 (each within the scatter of the next, the first and the last beyond it).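

In this assay, exchanging 3-fluoro-4-methylphenyl for 3-chloro-4-fluorophenyl on the nitrogen gives a number 3 percentage points lower from compound 1 to compound 4 (within the scatter). Read with a number 6 percentage points higher from compound 2 to compound 3 (within the scatter), this shows that the same entering group, replacing a different group on a different partner, leaves the read-out within the scatter in both pairs. No measured evidence bears on the reason for this result. On these data alone, whether a pyridine ring or a chain ending in a morpholine at this position would move the number beyond the scatter remains open.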